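The source may report more compounds than this note shows. Statements on the series, on what has been measured and on what is new or still open speak of the compounds shown alone.

Measured so far in a functional assay on NCI-H322M cells (Homo sapiens) for inhibition, read by sulforhodamine B assay, with a stated time of 48 h; a higher number here means a weaker inhibitor of growth, a lower number a stronger inhibitor of growth:

- compound 1, `COc1ccc(CNc2nc3cc(N)cc(N)c3nc2-c2ccccc2)cc1OC`: 47900 nM
- compound 2, `CCOC(=O)[C@H](CCC(=O)O)NC(=O)c1ccc(Oc2nc3cc(N)cc(N)c3nc2-c2ccccc2)cc1`: a limit, < 100000 nM
- compound 3, `COc1ccc(Sc2nc3cc(N)cc(N)c3nc2-c2ccccc2)cc1`: a limit, < 100000 nM

In this assay compound 1 gives a number, 47900 nM. For compound 2 the result is a limit of the assay, < 100000 nM. For compound 3 the result is likewise a limit, < 100000 nM. Two of the three results therefore sit at the limit of < 100000 nM in this assay, at which 2 of the 3 values shown sit, so compound 3 cannot be placed against compound 1 or compound 2 in this assay; all that is known is that its value lies on the same side of that limit as the others.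

The next compound, compound 4, `Nc1cc(N)c2nc(-c3ccccc3)c(Sc3ccc(F)cc3)nc2c1`, differs from compound 3 in one place: fluoro in place of methoxy on an aromatic carbon. Among the compounds with values here, no step between measured compounds touches this change, so no measured step gives a direction for it. The expectation is a step from compound 3 to compound 4 of a step that the limit leaves unreadable from compound 3 to compound 4 in this assay, which is no change beyond the usual scatter. On that basis compound 4 is estimated at 60000 nM in this assay, with a range from 20000 nM to 100000 nM, and a considerable chance that the assay again reports only a limit.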

Compound 4, concentration for total growth inhibition: 38000 nM
For compound 4 the middle estimate is 1.6-fold (0.20 log units) above the measured one; the measured number falls inside the stated range.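

No step can be read from compound 3 to compound 4 in this assay as compound 3 carries only a limit: the limit of < 100000 nM in this assay, at which 2 of the 4 values shown sit.

The compounds shown leave open the size and direction of the change when fluoro replaces methoxy on an aromatic carbon of this series.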